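Series notes: phenyl substitution at the oxadiazole-linked ring

A few compounds are considered here, and "the series" means these few. Any claim that something is new, unique, unknown or untested is made for them only; others in the source may bear on it.

Compound 2 `Cn1nc(-c2nnc(-c3ccc(O)cc3)o2)c2ccccc21` is known in an ADME assay on L02 cells (Homo sapiens) for cytotoxicity, read by MTT assay, with a stated time of 72 h (on this read-out lower numbers stand for stronger inhibition and higher numbers for weaker inhibition), only as a limit: compound 2 gives > 100000 nM, which is the assay's limit and not a number. Compound 1 `Cn1nc(-c2nnc(-c3ccccc3)o2)c2ccccc21` gives 84600 nM in this assay. The measured step of an at least 1.1-fold higher number from compound 1 to compound 2 (0.07 log units; that floor lies within the scatter) runs into that limit, as the limit of > 100000 nM in this assay, at which 1 of the 2 values shown sits, records, so the two values show no difference beyond the scatter.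

Compound 3 `Cc1cccc(-c2nnc(-c3nn(C)c4ccccc34)o2)c1` differs from compound 2 by 3-methylphenyl in place of 4-hydroxyphenyl on an aromatic carbon. For the measured compounds named here, no measured step bears directly on this change; the only step in hand, that from compound 1 to compound 2, was within the scatter, and it moved into the limit. Both measured values sit at the weak end of this assay, so no step beyond the scatter is expected from compound 2 to compound 3 in this assay, and the estimated step is an at least 1.1-fold lower number from compound 2 to compound 3 (0.04 log units; that floor lies within the scatter). Compound 3 is therefore expected near 90000 nM, with a range from 40000 nM to 200000 nM, and a fair chance that this assay again reports only a limit for compound 3.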

Compound 3, half-maximal inhibitory concentration: > 100000 nM
Compound 3 ended at the assay's limit; the forecaster's own chance of this, stated with the estimate: 45%; middle value at least 1.1-fold (0.04 log units) away from the limit.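

Notes on the 3-methylphenyl change: in this assay, the entering 3-methylphenyl has 0 hydrogen-bond donors and 0 hydrogen-bond acceptors where 4-hydroxyphenyl has 1 of each, yet compound 3 also ends at a limit of the assay, so the step between the two limits cannot be read. Methyl in place of hydrogen on the phenyl gives an at least 1.1-fold higher number from compound 1 to compound 3 (0.07 log units; that floor lies within the scatter), so this change, like the hydroxy change, shows nothing beyond the scatter. Neither substituent is yet seen to separate from the unsubstituted phenyl, and the readings stop at one end of the scale: the limit of > 100000 nM in this assay, at which 2 of the 3 values shown sit.

Still open, from the compounds shown here alone, is whether an amine, a carboxylic acid or a chlorine on this phenyl would give a number clearly lower than that of compound 1. Also open, going by these compounds, is whether 4-methylphenyl would read any differently from 3-methylphenyl.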